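The compounds below may be only part of what the source reports. "The series", "measured", "known", "first", "only" and "open" are said of these compounds alone.

Series notes, solubility. The shared core of compound 1 `C#CCNC(=O)C[C@H](NC(=O)c1ccc(C#Cc2ccccc2)cc1)C(=O)NO` carries a propargyl on an amide-type nitrogen; in a physicochemical assay for solubility (a lower number here means a less soluble compound, a higher number a more soluble compound), compound 1 gives 8000 nM. Compound 2 `NC(=O)C[C@H](NC(=O)c1ccc(C#Cc2ccccc2)cc1)C(=O)NO` gives 61000 nM, and compound 3 `COCCNC(=O)C[C@H](NC(=O)c1ccc(C#Cc2ccccc2)cc1)C(=O)NO` gives 78000 nM. Compound 3 holds the highest of the three numbers, though the step of a 1.3-fold higher number from compound 2 to compound 3 (0.11 log units; within the scatter) lies within the scatter; the step of a 9.8-fold higher number from compound 1 to compound 3 (0.99 log units; beyond the scatter) lies beyond the scatter, as does a 7.6-fold higher number from compound 1 to compound 2 (0.88 log units; beyond the scatter).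

Compound 4 `CSC[C@H](NC(=O)c1ccc(C#Cc2ccccc2)cc1)C(=O)NO` differs from compound 3 by methylsulfanyl in place of (2-methoxyethyl)carbamoyl on a saturated chain carbon, two bonds along the chain from an amide-type nitrogen and a carbonyl carbon. Within the data shown here, none of the measured steps removes the carbamoyl itself; they only vary what sits on the amide-type nitrogen, and those steps ran from within the scatter to modest. Among the measured compounds shown here, the measured set therefore gives no direct precedent, and the reading rests on the size of the change alone. The expectation for compound 4 is a modest step down, a 3.9-fold lower number from compound 3 to compound 4 (0.59 log units; beyond the scatter), with wide uncertainty. Compound 4 is estimated at 20000 nM, within 5000 nM to 80000 nM.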

Compound 4, solubility: 2000 nM
Beside the measured number, compound 4's estimate is 10-fold (1.00 log units) above it, outside the stated range (below it).
By their numbers in this assay, from the lowest: compound 4; then compound 1; then compounds 2 and 3 (each within the scatter of the next).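

Swapping the carbamoyl-bearing group on this saturated chain carbon for methylsulfanyl shows that this position can move the number in this assay much further than the earlier changes on the amide-type nitrogen: the change gives a 39-fold lower number from compound 3 to compound 4 (1.59 log units; beyond the scatter) and a 31-fold lower number from compound 2 to compound 4 (1.48 log units; beyond the scatter), both large steps. The same swap from the propargylcarbamoyl gives only a 4.0-fold lower number from compound 1 to compound 4 (0.60 log units; beyond the scatter), so the size of the drop depends on what the leaving carbamoyl carries, while compound 4 still holds the lowest number of the four, beyond the scatter of each of the others. Nothing available here bears on why these steps differ in size.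

Going by these compounds, whether a carboxylic acid, an amine or a longer chain ending in methylsulfanyl at this carbon would stay near compound 2 and compound 3 or fall towards compound 4 remains open. The compounds shown also leave open how far this position tolerates a group other than a carbamoyl.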